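A methyl group becomes trifluoromethyl, under a shared limit

The source may hold more compounds than are shown below. What is called first, only, known or untested is meant among the compounds shown, and "the series" means these compounds.

compound 1 `Cc1cc(N[C@H](CCCCN)C(=O)NO)cc(C)c1F` gives < 3
compound 2 `Cc1cc(N[C@H](CCCCNCc2cccc(F)c2)C(=O)NO)cc(C)c1F` gives < 3
compound 3 `Cc1ccc(CNCCCC[C@@H](Nc2cc(C)c(F)c(C)c2)C(=O)NO)cc1` gives < 3

In a physicochemical assay for lipophilicity, at pH 7.4 (on this read-out lower numbers stand for lower lipophilicity and higher numbers for higher lipophilicity), all three entries are limits of the assay and not numbers. Among the compounds with values here, the whole series so far comes down to the limit of < 3 in this assay, at which 3 of the 3 values shown sit, and so offers no exact value to build on. Compound 3 stands at < 3 and that entry is a limit.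

Compound 4 `Cc1cc(N[C@H](CCCCNCc2ccc(C(F)(F)F)cc2)C(=O)NO)cc(C)c1F` carries trifluoromethyl in place of methyl on an aromatic carbon, para to a large group. The counted change is trifluoromethyl in place of methyl on an aromatic carbon and it turns 4-methylphenyl into 4-(trifluoromethyl)phenyl.

The closest measured change is a step that the two limits leave unreadable from compound 2 to compound 3 and it too exchanges one substituted phenyl group for another. The steps a step that the two limits leave unreadable from compound 1 to compound 2 and a step that the two limits leave unreadable from compound 1 to compound 3 give no size either. Within the data shown here, no measured step therefore supplies a size or a direction to carry over to this change. The expectation rests instead on the limit of < 3 in this assay, at which 3 of the 3 values shown sit, and compound 4 is expected to be reported as a limit again, with no readable step. The estimated change is a step that the limit leaves unreadable from compound 3 to compound 4. For compound 4 the estimate is 2.5 with an expected range from 1.7 to 3.2 in the same assay.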

Compound 4, distribution coefficient: < 3
Compound 4 was reported as a limit (the forecaster's own chance of this, stated with the estimate: 75%); the middle value does not contradict the limit.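

In this assay compound 4 gives < 3, which is a limit and not a number. Within the data shown here, no step from compound 2 or compound 3 to compound 4 can therefore be read, and the series rests on one limit: the limit of < 3 in this assay, at which 4 of the 4 values shown sit. The compounds shown leave open how far compound 1, compound 2, compound 3 and compound 4 actually differ in this assay.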